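This account rests on a few compounds, and the source may have more. Where it says the series, first, only, none or still open, it means among the compounds named here.

In a functional assay on HepG2 cells (Homo sapiens) for inhibition, read by MTT assay, with a stated time of 72 h (on this read-out lower numbers stand for stronger inhibition and higher numbers for weaker inhibition), compound 1 `Cc1ccccc1-c1cc(C(=O)N2CCC3(CC2)CC(=O)c2nn(C(C)(C)C)cc2O3)c2ccccc2n1` reaches only a limit of the assay, > 10000 nM. Compound 2 `COc1ccc(-c2cc(C(=O)N3CCC4(CC3)CC(=O)c3nn(C(C)(C)C)cc3O4)c3ccccc3n2)cc1` gives 2780 nM, and compound 3 `CC(C)(C)n1cc2c(n1)C(=O)CC1(CCN(C(=O)c3cc(-c4ccc(N)cc4)nc4ccccc34)CC1)O2` gives 630 nM, the lowest number of the three. Compound 4 `CN(C)c1ccc(-c2cc(C(=O)N3CCC4(CC3)CC(=O)c3nn(C(C)(C)C)cc3O4)c3ccccc3n2)cc1` differs from compound 3 by dimethylamino in place of amino on an aromatic carbon, with dimethylamino in place of amino on an aromatic carbon. Among the measured compounds shown here, two measured steps touch this same place: an at least 15-fold lower number from compound 1 to compound 3 (1.20 log units; beyond the scatter) was large, and a 4.4-fold lower number from compound 2 to compound 3 (0.64 log units; beyond the scatter), with amino replacing methoxy, was modest. Neither tests dimethylamino itself, so the expectation leans on compound 2 at 2780 nM: a small upward move toward that number. The expected change is a 1.9-fold higher number from compound 3 to compound 4 (0.28 log units; within the scatter). Compound 4 is estimated at 1200 nM, with an expected range from 350 nM to 3500 nM.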

Compound 4, half-maximal inhibitory concentration: 1730 nM
The estimate for compound 4 lay 1.4-fold (0.16 log units) below the measured number; the measured number falls inside the stated range.
By their numbers in this assay, from the lowest: compound 3; then compounds 4 and 2 (each within the scatter of the next). At a limit, above all of these: compound 1.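

Replacing amino with dimethylamino gives a 2.7-fold higher number from compound 3 to compound 4 (0.44 log units; beyond the scatter), so at this place, para to a large group, the two nitrogen groups are not interchangeable. Dimethylamino in place of methoxy gives a 1.6-fold lower number from compound 2 to compound 4 (0.21 log units; within the scatter), so those two groups cannot be told apart here, and among the para-substituted compounds only the amino of compound 3 stands out. The remaining step, an at least 5.7-fold lower number from compound 1 to compound 4 (0.76 log units; beyond the scatter), rests on compound 1, whose value is only a limit: the limit of > 10000 nM in this assay, at which 1 of the 4 values shown sits.

Going by these compounds, whether methylamino, with a single methyl on the nitrogen, would behave like amino or like dimethylamino stays open. So does whether a hydroxyl group at this place would match amino.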